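Trading a sulfone-bearing pyrrolidine for plain piperidine

The source may report more compounds than this note shows. Statements on the series, on what has been measured and on what is new or still open speak of the compounds shown alone.

Compound 1 `Cc1nn([C@H](C)c2ccc(Cl)cc2Cl)c2nc(N3CC[C@H](N4CCC[C@H]4CCS(C)(=O)=O)[C@H](C)C3)cnc12` carries a methylsulfonylethyl-substituted pyrrolidine on the piperidine that hangs from its core, yet in an assay on CCRF-CEM cells for antagonist activity at C-C chemokine receptor type 4 (Homo sapiens), read by CellTiter-Glo, with stated times of 30 min and 60 min, in the presence of a further agent that is not named here (a higher number here means a weaker inhibitor, a lower number a stronger inhibitor), compound 1 is recorded as "not determined" (no result reported), so it offers no anchor. Two related compounds with a different core are measured: compound 2 `C[C@@H]1CC(c2cnc3c(C#N)nn([C@H](C)c4ccc(Cl)cc4Cl)c3n2)=CC[C@@H]1N1CCC[C@H]1C(N)=O` gives 1380 nM in this assay, and compound 3 `C[C@@H]1CC(c2cnc3c(C#N)nn([C@H](C)c4ccc(Cl)cc4Cl)c3n2)=CC[C@@H]1N1CCC[C@H]1CO` gives 70 nM. Among the compounds with values here, the single known step is a 20-fold lower number from compound 2 to compound 3 (1.29 log units; beyond the scatter), showing that the group on the saturated ring carbon can swing the result strongly. Compound 4 `Cc1nn([C@H](C)c2ccc(Cl)cc2Cl)c2nc(N3CC[C@H](N4CCCCC4)[C@H](C)C3)cnc12` differs from compound 1 by piperidin-1-yl in place of 2-(2-(methylsulfonyl)ethyl)pyrrolidin-1-yl on a saturated ring carbon. Within the data shown here, that change removes the sulfone side chain entirely rather than exchanging one group for another, so no measured step describes it directly, and the size and direction in this assay cannot be taken from compound 2 and compound 3 alone. Given that loss of substituent features is generally a sizeable move, compound 4 is expected to land around 250 nM, within a broad range of 30 nM to 2500 nM.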

Compound 4, half-maximal inhibitory concentration: 361 nM
Compound 4: middle estimate off by 1.4-fold (0.16 log units), on the low side; the measured number falls inside the stated range.
By their numbers in this assay, from the lowest: compound 3; then compound 4; then compound 2.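

No step can be read from compound 1 to compound 4 in this assay, and compound 4 differs from compound 2 and compound 3 in more than one place. The compounds shown leave open how piperidin-1-yl compares with 2-(2-(methylsulfonyl)ethyl)pyrrolidin-1-yl on this scaffold. No evidence bears on the result.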